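Pyridin-4-yl for phenyl on the shared core: cytotoxicity notes

The source may hold more compounds than are shown below. What is called first, only, known or untested is meant among the compounds shown, and "the series" means these compounds.

Measured so far:
compound 1 `Oc1cccc(-c2cc(-c3ccncc3)nc(-c3cccc(Cl)c3)c2)c1` — no number
compound 2 `Oc1cccc(-c2cc(-c3ccccc3)nc(-c3ccc(Cl)cc3)c2)c1` — 11600 nM

For the measured compounds named here, in an ADME assay on HEK293 cells (Homo sapiens) for cytotoxicity, read by CCK-8 assay and cell counting, with a stated time of 2 days (on this read-out higher numbers stand for weaker inhibition and lower numbers for stronger inhibition), compound 2 gives 11600 nM, the only number in hand. For compound 1 the outcome in this assay is "not determined" (no result reported), so nothing can be read from it. Compound 3 `Oc1cccc(-c2cc(-c3ccncc3)nc(-c3ccc(Cl)cc3)c2)c1` differs from compound 2 by pyridin-4-yl in place of phenyl on an aromatic carbon. Going by the values given here, no measured pair shows this exchange, so no step size is known; with a single number and no comparison the expected step in this assay is none beyond the scatter. Compound 3 is therefore expected near 14000 nM, range 5000 nM to 45000 nM, a step of a 1.2-fold higher number from compound 2 to compound 3 (0.08 log units; within the scatter).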

Compound 3, half-maximal inhibitory concentration: 2890 nM
Beside the measured number, compound 3's estimate is 4.8-fold (0.69 log units) above it, outside the stated range (below it).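

For the compounds shown here, the position next to the ring nitrogen responds to this exchange: in this assay pyridin-4-yl in place of phenyl gives a 4.0-fold lower number from compound 2 to compound 3 (0.60 log units; beyond the scatter) as the first readable step. The entering ring carries one hydrogen-bond acceptor where phenyl carries none. Nothing in hand gives a reason for the step.

From the compounds shown here alone, whether an aminomethyl group or a carboxylic acid on this ring, or a pyridin-3-yl group in its place, would move the number further stays open. Also open, going by these compounds, is whether the step carries over to the chlorophenyl arrangement of compound 1, which offers no comparison.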